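This account rests on a few compounds, and the source may have more. Where it says the series, first, only, none or still open, it means among the compounds named here.

Measured so far:
compound 1, `CCCCCCCCN(C)C(=O)Cn1cc(Cc2cnc(OCc3ccccc3)nc2)c(=O)nc1SCc1ccc(F)cc1`, 8%
compound 2, `CCCCCCCCN(C)C(=O)Cn1cc(Cc2cnc(=O)n(CC)c2)c(=O)nc1SCc1ccc(F)cc1`, 5%

Both were tested in a functional assay on a cell-free system (plasma, Oryctolagus cuniculus) for inhibition of platelet-activating factor acetylhydrolase (Homo sapiens), tested at 100 nM; on this read-out higher numbers stand for more inhibition at the one concentration tested (going by the name of the read-out) and lower numbers for less inhibition. In this assay compound 1 gives 8%, and compound 2 gives 5%. Compound 2 and compound 1 sit within the usual scatter of each other, so neither can be set apart from the other; both show only weak inhibition at the concentration tested.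

Compound 3, `CCCCCCCCN(C)C(=O)Cn1cc(Cc2cnc(=O)n(CC(=O)N3CCN(C(C)=O)CC3)c2)c(=O)nc1SCc1ccc(F)cc1`, has not yet been measured. It differs from compound 2 in one place: (4-acetylpiperazin-1-yl)carbonyl in place of methyl on a saturated chain carbon bound to an aromatic nitrogen. Within the data shown here, the two measured compounds are separated by more than one change, so no single step between them can be read, and the data give no guide to what such a replacement does. With compound 2 showing only 5%, the expectation for compound 3 is a step of about a number 2 percentage points higher from compound 2 to compound 3 (within the scatter), that is, nothing beyond the scatter, in either direction. Compound 3 is therefore estimated to give about 7% in this assay, in a range from -5% to 25%.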

Compound 3, a percentage reported as inhibition, at one concentration (the size of the read-out at that concentration, not a potency): 49%
Beside the measured number, compound 3's estimate is 42 percentage points below it; the measured number lies above the stated range.
By their numbers in this assay, from the lowest: compounds 2 and 1 (each within the scatter of the next); then compound 3.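

In this assay, the change at this position gives a step of a number 44 percentage points higher from compound 2 to compound 3 (beyond the scatter), so a saturated chain carbon bound to an aromatic nitrogen is a place where the substituent can decide the read-out, which the two earlier compounds could not show. The (4-acetylpiperazin-1-yl)carbonyl group brings 11 heavy atoms, one six-membered non-aromatic ring with 2 hetero atoms and 2 hydrogen-bond acceptors where methyl brought 1 heavy atom and none of these, and in this one pair that much larger group goes with more inhibition rather than less. No measurement here bears on why the step is this large.

A single pair cannot tell whether the step belongs to the carbonyl, the piperazine ring or the acetyl group, and a simple dimethylaminocarbonyl group, a piperazine with its ring amine free, or a carboxylic acid on the same chain carbon would begin to separate these parts. As far as these compounds go, it is also open how far the step holds when the other parts of compound 3 are varied, and what it would amount to as a potency, since the read-out comes from one concentration.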